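Pentyl for Phenyl on the Ring Nitrogen: Compound 4

The source may report more compounds than this note shows. Statements on the series, on what has been measured and on what is new or still open speak of the compounds shown alone.

Compound 1, `O=C(Nc1ccccc1)c1cccc(/C=C2\CC(=O)N(c3ccccc3)C2=O)c1`, gives in an ADME assay on HCT-116 cells (Homo sapiens) for cytotoxicity, read by MTT assay, with a stated time of 72 h (on this read-out lower numbers stand for stronger inhibition and higher numbers for weaker inhibition), a value of > 100000 nM, which is a limit of the assay rather than a number.
Compound 2, `CCc1cccc(NC(=O)c2cccc(/C=C3\CC(=O)N(c4ccccc4)C3=O)c2)c1`, gives in this assay 81200 nM.
Compound 3, `COc1ccc(NC(=O)c2cccc(/C=C3\CC(=O)N(c4ccccc4)C3=O)c2)cc1`, gives in this assay > 100000 nM, again only a limit of the assay.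

Compound 3 therefore has no number of its own; it sits at the limit of > 100000 nM in this assay, at which 2 of the 3 values shown sit. Of the steps among the measured compounds, a step that the two limits leave unreadable from compound 1 to compound 3 cannot be sized because both ends are limits, and an at least 1.2-fold higher number from compound 2 to compound 3 (0.09 log units; that floor lies within the scatter) is only a floor. Among the compounds with values here, the one readable-looking step, an at least 1.2-fold lower number from compound 1 to compound 2 (0.09 log units; that floor lies within the scatter), is also no more than a floor.

Compound 4, `CCCCCN1C(=O)C/C(=C\c2cccc(C(=O)Nc3ccc(OC)cc3)c2)C1=O`, differs from compound 3 by pentyl in place of phenyl on an amide-type nitrogen in a ring. Within the data shown here, every measured step changes the aromatic group on the amide-type nitrogen outside the ring; none touches the ring nitrogen, so no measured step bears directly on this change. Among the measured compounds shown here, what the three values do show is that every member of this series so far sits at or close to the limit.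

On that basis compound 4 is expected at 100000 nM, within a range of 40000 nM to 300000 nM. That estimate means a step of a number no higher from compound 3 to compound 4 (the limit leaves the size open), with the most likely outcome being another limit rather than a number.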

Compound 4, half-maximal inhibitory concentration: > 100000 nM
Compound 4 was reported as a limit; the forecaster's own chance of this, stated with the estimate: 65%; the middle value lies on the limit itself.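

No new step can be read: compound 3 and compound 4 are both reported only as limits of the assay, so the size of the change between them stays unknown, and the series now stands as follows: the limit of > 100000 nM in this assay, at which 3 of the 4 values shown sit.

Going by these compounds, whether pentyl in place of phenyl on an amide-type nitrogen in a ring changes the result in this assay at all remains open.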